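From Hydroxy to Methoxy on Compound 2

The compounds below may be only part of what the source reports. "The series", "measured", "known", "first", "only" and "open" are said of these compounds alone.

Measured in a functional assay on KBVIN cells (Homo sapiens) for cytotoxicity, read by sulforhodamine B assay, with a stated time of 3 days; a lower number here means that less compound is needed, a higher number that more compound is needed for the effect:
compound 1 `Cc1coc(-c2ccc3c(c2O)CCCC3(C)C)c1C(=O)O`: 4.7 uM
compound 2 `Cc1coc(-c2ccc3c(c2O)CCCC3(C)C)c1CO`: 19.9 uM
compound 3 `Cc1coc(-c2ccc3c(c2O)CCC3)c1C(=O)O`: 30.2 uM

Compound 2 lies within the scatter of compound 3, and its number is clearly higher than that of compound 1. Compound 4 `COc1c(-c2occ(C)c2CO)ccc2c1CCCC2(C)C` differs from compound 2 by methyl in place of hydrogen on an oxygen on an aromatic ring, with methyl in place of hydrogen on an oxygen on an aromatic ring. Going by the values given here, no measured step makes this change. Among the compounds with values here, the only step available, a 4.2-fold higher number from compound 1 to compound 2 (0.63 log units; beyond the scatter), concerns a different group and gives only a rough sense of size. No direction can therefore be argued, and the expected change is a 1.1-fold higher number from compound 2 to compound 4 (0.04 log units; within the scatter), none beyond the scatter. For compound 4 the estimate is 22 uM, with an expected range from 8 uM to 50 uM.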

Compound 4, concentration for half-maximal effect: 21.7 uM
Compound 4: middle estimate off by 1.0-fold (0.01 log units), on the high side; measured number inside the range.
By their numbers in this assay, from the lowest: compound 1; then compounds 2, 4 and 3 (each within the scatter of the next).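

In this assay, methoxy in place of hydroxy gives a 1.1-fold higher number from compound 2 to compound 4 (0.04 log units; within the scatter) and so, at this oxygen on an aromatic ring, the change leaves the number within the scatter. Going by these compounds alone, the earlier step concerned only the carboxy and hydroxymethyl groups, so this is the first reading at this oxygen. No evidence is available to explain this result.

The compounds shown leave open whether a longer chain such as ethoxy on this oxygen, or an amine in place of the hydroxy, would also stay within the scatter. They also leave open whether methoxy would do so alongside the carboxy group of compound 1.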